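Swapping the Morpholine Amide for a Methylpiperidine Amide

The source may report more compounds than this note shows. Statements on the series, on what has been measured and on what is new or still open speak of the compounds shown alone.

Of the compounds shown here, three sharing one core have been measured in an assay on isolated protein for inhibition of cathepsin S (Homo sapiens), read by fluorescence, with a stated time of 20 min; on this read-out lower numbers stand for stronger inhibition and higher numbers for weaker inhibition. Compound 1 `N#CCNC(=O)[C@@H]1C[C@@H](S(=O)(=O)CC2CC2)C[C@H]1C(=O)N1CCOCC1` gives 230 nM in this assay. Among the measured compounds shown here, compound 2 `N#CCNC(=O)[C@@H]1C[C@@H](S(=O)(=O)c2ccccc2C(F)(F)F)C[C@H]1C(=O)N1CCOCC1` gives 0.9 nM, and the only step so far, a 260-fold lower number from compound 1 to compound 2 (2.41 log units; beyond the scatter), concerns the group on the sulfonyl sulfur. Compound 3 `N#CC1(NC(=O)[C@@H]2C[C@@H](S(=O)(=O)c3ccccc3)C[C@H]2C(=O)N2CCOCC2)CC1` gives 0.7 nM, the lowest of the three numbers; its nearest neighbour is compound 2, whose number is higher but within the scatter, while compound 1 lies far above it, beyond the scatter.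

Compound 4 `CC1CCN(C(=O)[C@@H]2C[C@H](S(=O)(=O)c3ccccc3)C[C@H]2C(=O)NC2(C#N)CC2)CC1` has not yet been measured. It differs from compound 3 in one place: 4-methylpiperidin-1-yl in place of morpholin-4-yl on a carbonyl carbon. For the measured compounds named here, no measured step bears on this part of the molecule, since the single step recorded so far changes the group on the sulfonyl sulfur and leaves the amide untouched. Nothing in the data therefore points to a change in either direction, and the expected step of a 1.4-fold higher number from compound 3 to compound 4 (0.15 log units; within the scatter) is estimated to lie within the scatter. On that basis compound 4 is expected to give about 1 nM in this assay, with a range from 0.3 nM to 3.5 nM.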

Compound 4, half-maximal inhibitory concentration: 0.5 nM
Estimate against measurement, compound 4: 2.0-fold (0.30 log units) above, and the stated range covers the measured number.
By their numbers in this assay, from the lowest: compounds 4, 3 and 2 (each within the scatter of the next); then compound 1.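

In this assay, among the compounds shown here, the exchange of morpholin-4-yl for 4-methylpiperidin-1-yl on the carbonyl carbon gives a 1.4-fold lower number from compound 3 to compound 4 (0.15 log units; within the scatter), the first measured step at this amide, and it lies within the scatter. The hydrogen-bond acceptor counted on morpholin-4-yl is absent from 4-methylpiperidin-1-yl, and the group entering is larger by one heavy atom, yet compound 4 at 0.5 nM remains within the scatter of compound 3, so this position accepted this particular change without a readable shift in the number. The data at hand offer no evidence on why the number responds so little to this exchange.

Going by these compounds, whether the same holds for a ring carrying a basic amine, such as piperazin-1-yl, for a piperidine bearing a carboxylic acid, or for an open-chain diethylamino group on the carbonyl carbon remains open. On these data alone, this step also rests on a single pair of compounds, so it is unknown whether the exchange would behave alike with cyclopropylmethyl or 2-(trifluoromethyl)phenyl on the sulfonyl sulfur, or with the cyanomethyl amide of compounds 1 and 2.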